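Moving the fluorine on the aryl group of compound 1

The compounds below may be only part of what the source reports. "The series", "measured", "known", "first", "only" and "open" are said of these compounds alone.

Compound 1 `CCCc1nc(-c2ccccc2)c(CNCCCN2CCN(c3ccc(F)cc3)CC2)o1`: 62.5%
Compound 2 `CCCc1nc(-c2ccccc2)c(CNCCN2CCN(c3cccc(Cl)c3)CC2)o1`: 51.2%

In an assay on HEK293 cells for inhibition of Voltage-dependent T-type calcium channel subunit alpha-1G (Homo sapiens), read by fluorescence, tested at 10 uM (a higher number here means more inhibition at the concentration tested (going by the name of the read-out), a lower number less inhibition), compound 1 gives 62.5%, the higher of the two numbers, while compound 2 gives 51.2%, a drop beyond the usual scatter. Compound 3 `CCCc1nc(-c2ccccc2)c(CNCCCN2CCN(c3cccc(F)c3)CC2)o1` differs from compound 1 only in one way: 3-fluorophenyl in place of 4-fluorophenyl on an amine nitrogen in a ring. Among the compounds with values here, no measured pair differs in this place alone, so there is no measured step to lean on. A change this small is expected to shift the number only a little, by a number 5.5 percentage points lower from compound 1 to compound 3 (within the scatter), probably within the scatter. Compound 3 is therefore estimated at 57%, with a range from 40% to 74%.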

Compound 3, a percentage reported as inhibition, at one concentration (the size of the read-out at that concentration, not a potency): 68.9%
For compound 3 the middle estimate is 11.9 percentage points below the measured one; low and high end bracket the measured number.
By their numbers in this assay, from the lowest: compound 2; then compounds 1 and 3 (each within the scatter of the next).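

Moving the fluorine, with 3-fluorophenyl in place of 4-fluorophenyl on the amine nitrogen in the ring, gives the first measured step at this position: in this assay it is a number 6.4 percentage points higher from compound 1 to compound 3 (within the scatter), so the two placements cannot be told apart here. Nothing available explains this result.

Still open, as far as these compounds go, is whether a larger change at this place would matter, such as a methoxy group in place of the fluorine or a plain phenyl. From the compounds shown here alone, compound 2 differs from compound 1 in more than one place, so the effect of its shorter chain alone also remains open.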